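The source may hold more compounds than are shown below. What is called first, only, known or untested is meant among the compounds shown, and "the series" means these compounds.

Measured in a functional assay on A-431 cells (Homo sapiens) for cytotoxicity, read by MTT assay, with a stated time of 24 h; on this read-out lower numbers stand for stronger inhibition and higher numbers for weaker inhibition:
compound 1, `COc1ccc(/C=C\C(=O)O)c(OCc2cn(-c3cccc(C#N)c3)nn2)c1CC=C(C)C`, 22900 nM
compound 2, `COc1ccc(/C=C\C(=O)O)c(OCc2cn(-c3ccccc3)nn2)c1CC=C(C)C`, 21200 nM
compound 3, `COc1ccc(/C=C\C(=O)O)c(OCc2cn(-c3ccccc3C(=O)N3CCC(O)C3)nn2)c1CC=C(C)C`, 31500 nM

All three numbers sit within the usual scatter of one another, so compound 1 stands within the scatter of both compound 2 and compound 3. The unmeasured compound 4, `COc1ccc(/C=C\C(=O)O)c(OCc2cn(-c3ccccc3C#N)nn2)c1CC=C(C)C`, differs from compound 1 by 2-cyanophenyl in place of 3-cyanophenyl on an aromatic nitrogen. Among the measured compounds shown here, no measured step moves the cyano group from one ring carbon to another; the closest comparisons, a 1.1-fold lower number from compound 1 to compound 2 (0.03 log units; within the scatter) and a 1.5-fold higher number from compound 2 to compound 3 (0.17 log units; within the scatter), change what the phenyl ring carries without any shift beyond the scatter. The expected step of a 1.0-fold higher number from compound 1 to compound 4 (0.00 log units; within the scatter) is therefore no change beyond the scatter. Compound 4 is estimated at 23000 nM, with a range from 12000 nM to 45000 nM.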

Compound 4, half-maximal inhibitory concentration: 10300 nM
Estimate against measurement, compound 4: 2.2-fold (0.35 log units) above; measured number below the stated range.
By their numbers in this assay, from the lowest: compound 4; then compounds 2, 1 and 3 (each within the scatter of the next).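

In this assay, among the compounds shown here, where the cyano group sits on the phenyl ring now counts: 2-cyanophenyl in place of 3-cyanophenyl gives a 2.2-fold lower number from compound 1 to compound 4 (0.35 log units; beyond the scatter) as the first step beyond the scatter. The steps of a 2.1-fold lower number from compound 2 to compound 4 (0.31 log units; beyond the scatter) and a 3.1-fold lower number from compound 3 to compound 4 (0.49 log units; beyond the scatter) show that compound 4 also separates from the other two compounds, so the series no longer sits within a single band. No measurement at hand accounts for this shift.

As far as these compounds go, whether the lower number belongs to the nitrile itself or would follow other groups at that place stays open. An amine, a chlorine or a carboxylic acid in place of the cyano of 2-cyanophenyl would separate these two readings.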